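A few compounds are considered here, and "the series" means these few. Any claim that something is new, unique, unknown or untested is made for them only; others in the source may bear on it.

Measured so far:
- compound 1, `O=C(N/N=C/c1ccccc1O)c1cc(-c2ccccc2)nn1Cc1ccc(Cl)nc1`: 440 nM
- compound 2, `COc1ccc(/C=N/NC(=O)c2cc(-c3ccccc3)nn2Cc2ccc(Cl)nc2)cc1`: "not determined" (no result reported)

In a physicochemical assay on A549 cells for solubility, read by microscopy, with a stated time of 24 h (a lower number here means a stronger inhibitor, a higher number a weaker inhibitor), compound 1 gives 440 nM. Compound 2 stands nowhere on the numbers: this assay reports no value for it, so the series holds a single measured point. Compound 3, `O=C(N/N=C/c1ccco1)c1cc(-c2ccccc2)nn1Cc1ccc(Cl)nc1`, differs from compound 2 by furan-2-yl in place of 4-methoxyphenyl on a carbon with a double bond to nitrogen. Among the measured compounds shown here, no measured step informs this change, and compound 2 itself lacks a value, so no direction beyond the scatter can be claimed in this assay. Compound 3 is estimated at 600 nM, with a range from 150 nM to 2500 nM, anchored only on compound 1.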

Compound 3, half-maximal inhibitory concentration: 19400 nM
For compound 3 the middle estimate is 32-fold (1.51 log units) below the measured one; measured number outside the range, above it.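

In this assay, the carbon with a double bond to nitrogen proves sensitive to its substituent: furan-2-yl in place of 2-hydroxyphenyl gives a 44-fold higher number from compound 1 to compound 3 (1.64 log units; beyond the scatter), well beyond the scatter. Among the compounds shown here, this is the first readable step, and it shows that a change at this one place can move the number substantially. Nothing measured here accounts for the step. Still open, going by these compounds, is whether the step follows from losing 2-hydroxyphenyl or from gaining furan-2-yl. Also open, on these data alone, is how a 2-aminophenyl or thiophen-2-yl group on that carbon would read.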